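Adding a chloro group beside the trifluoromethyl of compound 3

A few compounds are considered here, and "the series" means these few. Any claim that something is new, unique, unknown or untested is made for them only; others in the source may bear on it.

Compound 1 `O=C(Nc1cccc(-n2cc(-c3ccncc3)c(-c3ccc(Cl)c(O)c3)n2)c1)Nc1cccc(C(F)(F)F)c1` gives 3830 nM in a functional assay on SW-620 cells (Homo sapiens) for inhibition, read by sulforhodamine B assay, with a stated time of 48 h; on this read-out lower numbers stand for stronger inhibition of growth and higher numbers for weaker inhibition of growth.
Compound 2 `COc1cc(-c2nn(-c3cccc(NC(=O)Nc4cc(C(F)(F)F)cc(C(F)(F)F)c4)c3)cc2-c2ccncc2)ccc1Cl` gives 715 nM in this assay.
Compound 3 `COc1cc(-c2nn(-c3cccc(NC(=O)c4cccc(C(F)(F)F)c4)c3)cc2-c2ccncc2)ccc1Cl` gives 2310 nM in this assay.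

Among these three numbers, compound 3 holds the second highest. Its nearest neighbour is compound 1, whose value sits a little higher but within the scatter of the method, so the two cannot be told apart. Compound 2, a urea with two trifluoromethyl groups, sits well below compound 3, and that gap is beyond the scatter, so compound 2 is the clearer growth inhibitor of the pair.

Compound 4 `COc1cc(-c2nn(-c3cccc(NC(=O)c4ccc(Cl)c(C(F)(F)F)c4)c3)cc2-c2ccncc2)ccc1Cl` has not yet been measured. It differs from compound 3 in one place: chloro in place of hydrogen on an aromatic carbon. Put more simply, a chloro group enters on the aromatic ring of the amide part, ortho to the trifluoromethyl group and para to the large group, so that the 3-(trifluoromethyl)phenyl becomes a 4-chloro-3-(trifluoromethyl)phenyl.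

Among the measured compounds shown here, no measured pair in this set shows this exact change, so any expectation rests on compound 3 alone. A modest move toward a lower number is expected, as a 1.8-fold lower number from compound 3 to compound 4 (0.25 log units; within the scatter), though a result within the scatter of compound 3 would not be surprising. On that basis compound 4 is estimated at 1300 nM in this assay, with a likely range from 400 nM to 4000 nM.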

Compound 4, concentration for 50% growth inhibition: 4750 nM
Estimate against measurement, compound 4: 3.7-fold (0.56 log units) below; measured number outside the range, above it.
By their numbers in this assay, from the lowest: compound 2; then compounds 3, 1 and 4 (each within the scatter of the next, the first and the last beyond it).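

In this assay, among the compounds shown here, this is the first comparison in the set where only one place changes, so the effect of a single group can be read directly. Chloro in place of hydrogen, on the aromatic carbon ortho to the trifluoromethyl group and para to the large group, gives a 2.1-fold higher number from compound 3 to compound 4 (0.31 log units; beyond the scatter); since a higher number stands for weaker inhibition of growth, turning the 3-(trifluoromethyl)phenyl into a 4-chloro-3-(trifluoromethyl)phenyl costs a modest amount of activity in this amide series rather than adding to it. Nothing measured here gives a reason for this loss, so the step stands as an observation from one pair of compounds.

On these data alone, it remains open whether the loss belongs to chloro itself or to any group placed on this carbon, and a fluoro group or an amine at the same place would help to separate those two readings. It is also unknown whether the same chloro change would shift the number in the same direction in a urea such as compound 1, which has the same 3-(trifluoromethyl)phenyl group.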